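Ethyl for methyl on the ring amide nitrogen

The source may hold more compounds than are shown below. What is called first, only, known or untested is meant among the compounds shown, and "the series" means these compounds.

Compound 1 `CN1C(=O)C(O)(Cc2nnn[nH]2)c2cc(Cl)ccc21` carries chloro on the aromatic ring and methyl on the amide-type nitrogen. In a functional assay on BT-549 cells (Homo sapiens) for antiproliferative activity, read by MTT assay, with a stated time of 48 h (a higher number here means a weaker inhibitor, a lower number a stronger inhibitor), compound 1 gives > 100000 nM, which is a limit of the assay and not a number. Compound 2 `CCN1C(=O)C(O)(Cc2nnn[nH]2)c2cc(Cl)ccc21` differs by methyl in place of hydrogen on a saturated chain carbon bound to an amide-type nitrogen in a ring. In this assay compound 2 gives 85400 nM. The resulting step is an at least 1.1-fold lower number from compound 1 to compound 2 (0.06 log units; that floor lies within the scatter); its floor is set by the limit of > 100000 nM in this assay, at which 2 of the 3 values shown sit. Compound 3 `Cc1ccc2c(c1)C(O)(Cc1nnn[nH]1)C(=O)N2C` differs from compound 1 by methyl in place of chloro on an aromatic carbon. In this assay compound 3 gives > 100000 nM, again a limit of the assay. That pair leaves a step that the two limits leave unreadable from compound 1 to compound 3. Compound 4 `CCN1C(=O)C(O)(Cc2nnn[nH]2)c2cc(C)ccc21` is not yet measured in this assay and differs from compound 3 by methyl in place of hydrogen on a saturated chain carbon bound to an amide-type nitrogen in a ring, the same change as from compound 1 to compound 2. The expectation rests on the step of an at least 1.1-fold lower number from compound 1 to compound 2 (0.06 log units; that floor lies within the scatter), which lies within the scatter. Compound 4 is therefore expected near 90000 nM, between 40000 nM and 200000 nM. The expected step is an at least 1.1-fold lower number from compound 3 to compound 4 (0.04 log units; that floor lies within the scatter), and a limit rather than a number remains a real possibility.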

Compound 4, half-maximal inhibitory concentration: > 100000 nM
Compound 4 gave a limit, no number; the forecaster's own chance of this, stated with the estimate: 55%; at least 1.1-fold (0.04 log units) between middle value and limit.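

In this assay compound 4 gives > 100000 nM as a limit of the assay and not a number. Going by these compounds alone, the one readable new step is an at least 1.1-fold higher number from compound 2 to compound 4 (0.06 log units; that floor lies within the scatter) for methyl in place of chloro on an aromatic carbon, so it does not separate the two groups with ethyl held on the ring nitrogen. Steps with limits at both ends cannot be read, so methyl to ethyl on the core of compound 3 neither repeats nor contradicts the result on the core of compound 1, and the series mostly rests at one ceiling: the limit of > 100000 nM in this assay, at which 3 of the 4 values shown sit.

On these data alone, a longer chain such as propyl or butyl on the amide-type nitrogen remains open. So does an amine or a carboxylic acid at the end of that chain.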